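Furanylmethyl to Cyclohexyl on the Amide Nitrogen

The compounds below may be only part of what the source reports. "The series", "measured", "known", "first", "only" and "open" are said of these compounds alone.

Compound 3 `COc1cc(-c2cc(C(=O)O)c3ccccc3n2)ccc1OCC(=O)NCc1ccco1` shares its core with compound 1 `COc1cc(-c2cc(C(=O)O)c3ccccc3n2)ccc1OCC(=O)Nc1ccccc1` and compound 2 `COc1cc(-c2cc(C(=O)O)c3ccccc3n2)ccc1OCC(=O)Nc1ccccc1C` and differs from them only in the group on the amide-type nitrogen. In an ADME assay on HaCaT cells (Homo sapiens) for inhibition (a higher number here means a weaker inhibitor, a lower number a stronger inhibitor), compound 3 stands at the limit of > 300000 nM. Compound 1 likewise stands at the limit of > 300000 nM. Compound 2 gives 230000 nM in this assay. The step of an at least 1.3-fold lower number from compound 1 to compound 2 (0.11 log units; that floor lies within the scatter) sits within the scatter, the step of an at least 1.3-fold higher number from compound 2 to compound 3 (0.11 log units; that floor lies within the scatter) sits within the scatter as well, and a step that the two limits leave unreadable from compound 1 to compound 3. Within the data shown here, two of the three values sit at the same limit (the limit of > 300000 nM in this assay, at which 2 of the 3 values shown sit), so none of the measured steps shows a movement beyond the scatter. Compound 4 `COc1cc(-c2cc(C(=O)O)c3ccccc3n2)ccc1OCC(=O)NC1CCCCC1` differs from compound 3 by cyclohexyl in place of (furan-2-yl)methyl on an amide-type nitrogen. Since none of the three measured steps leaves the scatter, the account expects for compound 4 no step beyond the scatter, a number no higher from compound 3 to compound 4 (the limit leaves the size open), and most likely a limit again. Compound 4 is estimated at 300000 nM, with a range from 150000 nM to 600000 nM.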

Compound 4, half-maximal inhibitory concentration: > 300000 nM
Compound 4 ended at the assay's limit; the forecaster's own chance of this, stated with the estimate: 65%; the middle value lies on the limit itself.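

In this assay, among these compounds, compound 4 is a limit of the assay and not a number, so a non-aromatic carbon ring on the amide-type nitrogen joins the furan-bearing group and the unsubstituted phenyl at the same ceiling: the limit of > 300000 nM in this assay, at which 3 of the 4 values shown sit. The one step that can be read, an at least 1.3-fold higher number from compound 2 to compound 4 (0.11 log units; that floor lies within the scatter), gives only a floor, so cyclohexyl in place of 2-methylphenyl shows no movement beyond the scatter, though its true size stays open. The steps to compound 4 from compound 1 and compound 3 cannot be read, so this change from (furan-2-yl)methyl to cyclohexyl has no measurable size.

On these data alone, how far compound 1, compound 3 and compound 4 lie past the limit remains open. So does whether a basic amine, a carboxylic acid or a longer chain on this nitrogen would give a clearly lower number.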